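Removing the Bromine: What to Expect for Compound 4

A few compounds are considered here, and "the series" means these few. Any claim that something is new, unique, unknown or untested is made for them only; others in the source may bear on it.

Compound 1, `COc1ccc(/C(Cl)=C/C=C(\C#N)C(=O)c2c(C)[nH]c3ccccc23)cc1OC`: > 100000 nM
Compound 2, `COc1cc(/C(Cl)=C/C=C(\C#N)C(=O)c2c[nH]c3ccccc23)cc(OC)c1OC`: > 100000 nM
Compound 3, `COc1ccc(/C(Cl)=C/C=C(\C#N)C(=O)c2c[nH]c3ccc(Br)cc23)cc1OC`: > 100000 nM

In a functional assay on MCF7 cells (Homo sapiens) for cytotoxicity, read by sulforhodamine B assay, with a stated time of 48 h (a higher number here means that more compound is tolerated, a lower number that less compound is tolerated), compound 1 gives > 100000 nM, which is a limit of the assay rather than a measured number. Compound 2 also stops at the limit, > 100000 nM. Compound 3 stands in the same place: its value in this assay, > 100000 nM, is again a limit and not a number. So compound 3 is not set apart from the other two; all three share (the limit of > 100000 nM in this assay, at which 3 of the 3 values shown sit).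

Compound 4, `COc1ccc(/C(Cl)=C/C=C(\C#N)C(=O)c2c[nH]c3ccccc23)cc1OC`, differs from compound 3 in one spot: hydrogen in place of bromo on an aromatic carbon. Within the data shown here, no pair of measured compounds differing in a single place is available, so there is no measured step to lean on. Because every compound shown sits at the limit of > 100000 nM in this assay, at which 3 of the 3 values shown sit, the expectation for the change from compound 3 to compound 4 in this assay is no movement beyond the scatter, with the result most likely remaining a limit. The estimated step is a number no higher from compound 3 to compound 4 (the limit leaves the size open). Compound 4 is therefore expected to give about 100000 nM in this assay, within a range from 30000 nM to 300000 nM.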

Compound 4, concentration lethal to 50% of the cells: > 100000 nM
Compound 4 gave a limit, no number (the forecaster's own chance of this, stated with the estimate: 80%); the middle value sits exactly at the limit.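

Compound 4 also gives a limit rather than a number, so no new step can be read between it and compound 1, compound 2 or compound 3: the limit of > 100000 nM in this assay, at which 4 of the 4 values shown sit.

Where the true values of these compounds lie, and whether swapping bromo, methoxy or methyl for hydrogen changes them at all, stays open.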